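Amine variation on the shared core in topoisomerase 1 inhibition

This account rests on a few compounds, and the source may have more. Where it says the series, first, only, none or still open, it means among the compounds named here.

Measured so far:
compound 1 `CN(C)c1ccc2nc(-c3cccc4ccccc34)[nH]c(=O)c2c1`: 2.4%
compound 2 `Cc1ccc2nc(-c3cccc4ccccc34)[nH]c(=O)c2c1`: "not determined" (no result reported)
compound 3 `O=c1[nH]c(-c2cccc3ccccc23)nc2ccc(N3CCCCC3)cc12`: 33.4%

Among the measured compounds shown here, in an assay on isolated protein for inhibition of DNA topoisomerase 1 (Homo sapiens), with a stated time of 30 min, tested at 20 uM (on this read-out lower numbers stand for a weaker effect and higher numbers for a stronger effect at the one concentration tested), compound 3 stands highest of the two numbers available; its nearest neighbour is compound 1, and the step of a number 31 percentage points higher from compound 1 to compound 3 (beyond the scatter) is the only measured change, with compound 2 giving no number. Compound 4 `CCN(CC)c1ccc2nc(-c3cccc4ccccc34)[nH]c(=O)c2c1` differs from compound 3 by diethylamino in place of piperidin-1-yl on an aromatic carbon.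

For the measured compounds named here, the single step that bears on this change is a number 31 percentage points higher from compound 1 to compound 3 (beyond the scatter), which shows that swapping the amine on that aromatic carbon can move this assay by a large amount. Diethylamino is neither the dimethylamino of compound 1 nor the piperidin-1-yl of compound 3, so the direction is uncertain; a loss relative to compound 3 seems somewhat more likely than a gain, but the range must span both measured values. Compound 4 is therefore expected to give 18%, within 2% to 38%, an estimated step of a number 15.4 percentage points lower from compound 3 to compound 4 (beyond the scatter).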

Compound 4, a percentage reported as inhibition, at one concentration (the size of the read-out at that concentration, not a potency): 25.5%
Beside the measured number, compound 4's estimate is 7.5 percentage points below it; low and high end bracket the measured number.
By their numbers in this assay, from the lowest: compound 1; then compounds 4 and 3 (each within the scatter of the next).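

In this assay the open-chain diethylamino group and the ring of piperidin-1-yl cannot be told apart, with a number 7.9 percentage points lower from compound 3 to compound 4 (within the scatter) as the step between them. Diethylamino in place of dimethylamino still gives a number 23.1 percentage points higher from compound 1 to compound 4 (beyond the scatter) and so, among these three compounds, a higher number at this aromatic carbon does not depend on a ring, and only the dimethylamino of compound 1 stays low. Nothing at hand accounts for the difference between these amines.

Going by these compounds, it remains open whether a pyrrolidin-1-yl or morpholin-4-yl group on this carbon would fall with compound 3 and compound 4 or with compound 1. On these data alone, whether a longer chain, as in dipropylamino, would raise the number further also remains open.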